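Trimethoxybenzoyl aminothiophenes: aryl variation at the sulfur-adjacent carbon

The source may hold more compounds than are shown below. What is called first, only, known or untested is meant among the compounds shown, and "the series" means these compounds.

Measured so far:
compound 1 `COc1cc(C(=O)c2sc(-c3ccc(C)cc3)cc2N)cc(OC)c1OC`, 16 nM
compound 2 `COc1cc(C(=O)c2sc(-c3ccc(Cl)c(Cl)c3)cc2N)cc(OC)c1OC`, 270 nM
compound 3 `COc1ccc(-c2cc(N)c(C(=O)c3cc(OC)c(OC)c(OC)c3)s2)cc1OC`, 20 nM

In a functional assay on MOLT-4 cells (Homo sapiens) for antiproliferative activity (on this read-out higher numbers stand for weaker inhibition and lower numbers for stronger inhibition), compound 3 stands second highest of the three numbers; its nearest neighbour is compound 1, and a 1.3-fold higher number from compound 1 to compound 3 (0.10 log units; within the scatter) lies within the scatter, while the gap to compound 2 is large: a 14-fold lower number from compound 2 to compound 3 (1.13 log units; beyond the scatter).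

Compound 4 `COc1cc(C(=O)c2sc(-c3ccc(Br)cc3)cc2N)cc(OC)c1OC` is not yet measured. The change from compound 3 is 4-bromophenyl in place of 3,4-dimethoxyphenyl on an aromatic carbon.

Within the data shown here, two measured steps bear on this. Removing the 3,4-dimethoxyphenyl for a 3,4-dichlorophenyl gives the large step that reverses a 14-fold lower number from compound 2 to compound 3 (1.13 log units; beyond the scatter), and exchanging 4-methylphenyl for 3,4-dichlorophenyl gives a 17-fold higher number from compound 1 to compound 2 (1.23 log units; beyond the scatter). A 4-bromophenyl carries a single halogen, so a halogen-bearing aryl is expected to weaken inhibition in this assay, but less than the dichloro case; a moderate step upward is expected, a 2.5-fold higher number from compound 3 to compound 4 (0.40 log units; beyond the scatter). Compound 4 is therefore estimated at 50 nM, with a range from 12 nM to 200 nM.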

Compound 4, half-maximal inhibitory concentration: 92 nM
Compound 4: middle estimate off by 1.8-fold (0.26 log units), on the low side; measured number inside the range.
By their numbers in this assay, from the lowest: compounds 1 and 3 (each within the scatter of the next); then compound 4; then compound 2.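

In this assay, bromo in place of methyl gives a 5.8-fold higher number from compound 1 to compound 4 (0.76 log units; beyond the scatter) and 4-bromophenyl in place of 3,4-dimethoxyphenyl gives a 4.6-fold higher number from compound 3 to compound 4 (0.66 log units; beyond the scatter) at this carbon next to the ring sulfur, so a single halogen on the aryl group is enough to raise the number. Against the dichloro case, 4-bromophenyl gives a 2.9-fold lower number from compound 2 to compound 4 (0.47 log units; beyond the scatter) in this series, so compound 4 occupies an intermediate level and the position does not split into just two levels. Among these four compounds, the two halogen-bearing aryl groups give the higher numbers and none goes against this, but no evidence on the cause is at hand.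

The compounds shown cannot separate the identity of the halogen from the number of halogens, which a 4-chlorophenyl would help to resolve. Also open, going by these compounds, is how this position responds to an aryl group carrying an amine or a carboxylic acid.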